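Swapping the methoxyphenyl for fluorophenyl on the shared core

A few compounds are considered here, and "the series" means these few. Any claim that something is new, unique, unknown or untested is made for them only; others in the source may bear on it.

Compound 1 `COc1ccc(-c2c(-c3ccc(S(C)(=O)=O)cc3)oc3ccccc3c2=O)cc1` was examined in an assay on isolated protein for inhibition of prostaglandin G/H synthase 1 (Mus musculus), tested at 10 ug/mL; a higher number here means more inhibition at the concentration tested (going by the name of the read-out), a lower number less inhibition. In this assay compound 1 gives < 5%, which is a limit of the assay rather than a number. Two related compounds set the frame. Compound 2 `CSc1ccc(-c2c(-c3ccc(S(N)(=O)=O)cc3)oc3ccccc3c2=O)cc1` gives 90% in this assay. Compound 3 `CS(=O)(=O)c1ccc(-c2oc3ccccc3c(=S)c2-c2ccc(Cl)c(Cl)c2)cc1` gives < 5%, again a limit and not a number. Compound 1 therefore sits at the floor of what has been observed, and the limit of < 5% in this assay, at which 2 of the 3 values shown sit, shows that it shares this floor with one other compound, while only compound 2 stands clearly away from it.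

Compound 4 `CS(=O)(=O)c1ccc(-c2oc3ccccc3c(=O)c2-c2cccc(F)c2)cc1` has not yet been measured in this assay. It differs from compound 1 in one place: 3-fluorophenyl in place of 4-methoxyphenyl on an aromatic carbon. Among the measured compounds shown here, no pair of measured compounds traces this particular change, so its effect is unknown, and because the value of compound 1 is itself only a limit, any step can be read in one direction only. The step from compound 1 to compound 4 is expected to be a number no lower from compound 1 to compound 4 (the limit leaves the size open), that is, nothing beyond the usual scatter. Compound 4 is expected to give 5% in this assay, within a range from 0% to 20%, and will most likely be reported again as a limit.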

Compound 4, a percentage reported as inhibition, at one concentration (the size of the read-out at that concentration, not a potency): < 5%
Compound 4: a limit, no number; the forecaster's own chance of this, stated with the estimate: 65%; the middle value sits exactly at the limit.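

In this assay compound 4 gives < 5%, which is a limit of the assay and not a number. Among the compounds shown here, compound 1 also rests on a limit, so no step between compound 1 and compound 4 can be read. The compounds shown leave open whether 3-fluorophenyl in place of 4-methoxyphenyl changes inhibition at all: the limit of < 5% in this assay, at which 3 of the 4 values shown sit.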